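From 4-bromophenyl to 3-hydroxyphenyl: notes on compound 3

The compounds below may be only part of what the source reports. "The series", "measured", "known", "first", "only" and "open" are said of these compounds alone.

In a functional assay on HepG2 cells (Homo sapiens) for inhibition, read by MTT assay, with a stated time of 24 h (on this read-out higher numbers stand for weaker inhibition and lower numbers for stronger inhibition), compound 1 `CC1(C)[C@H]2CC[C@]1(C)N(Cc1cn(-c3ccccc3)nn1)C(=O)C2` gives 90 nM and compound 2 `CC1(C)[C@H]2CC[C@]1(C)N(Cc1cn(-c3ccc(Br)cc3)nn1)C(=O)C2` gives 110 nM as its half-maximal inhibitory concentration. Compound 2 therefore sits within the scatter of compound 1, and the two cannot be ranked. The change from compound 2 to compound 3 `CC1(C)[C@H]2CC[C@]1(C)N(Cc1cn(-c3cccc(O)c3)nn1)C(=O)C2` reads 3-hydroxyphenyl in place of 4-bromophenyl on an aromatic nitrogen and in words is 3-hydroxyphenyl in place of 4-bromophenyl on an aromatic nitrogen of a five-membered aromatic ring with 3 nitrogen, while the shared core stays the same. Going by the values given here, no measured compound carries a hydroxyl group, so the data hold no direct precedent for the entering group. Among the compounds with values here, the only measured step is a 1.2-fold higher number from compound 1 to compound 2 (0.09 log units; within the scatter) for bromo in place of hydrogen on an aromatic carbon. On that single small step, no shift beyond the scatter is expected for compound 3 in this assay although one step is thin ground. The expected step is a 1.1-fold higher number from compound 2 to compound 3 (0.04 log units; within the scatter) and the range is kept wide. Compound 3 is estimated at 120 nM with an expected range from 45 nM to 350 nM on this read-out.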

Compound 3, half-maximal inhibitory concentration: 70 nM
The estimate for compound 3 lay 1.7-fold (0.23 log units) above the measured number; low and high end bracket the measured number.
By their numbers in this assay, from the lowest: compounds 3, 1 and 2 (each within the scatter of the next).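

At this place, on an aromatic nitrogen of a five-membered aromatic ring with 3 nitrogen, the series now tolerates a change in the aryl group itself and not only the addition of bromo to the phenyl ring: in this assay the exchange gives a 1.6-fold lower number from compound 2 to compound 3 (0.20 log units; within the scatter) and leaves the read-out unresolved from that of the bromo compound. Adding a hydroxyl group to the phenyl ring, the first change to bring in a hydrogen-bond donor and a hydrogen-bond acceptor, gives a 1.3-fold lower number from compound 1 to compound 3 (0.11 log units; within the scatter) and likewise separates nothing from the unsubstituted phenyl compound, so that bromo and hydroxy cannot be ranked against hydrogen on these numbers. Nothing available here bears on the reason for these results.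

Still open, on these data alone, is whether any group on this aryl ring can move the number beyond the scatter, since the three compounds do not yet mark a limit to what the position accepts in either direction. An amine or a carboxylic acid on the phenyl ring would test this further, and a longer chain between the aromatic nitrogen and the phenyl ring would show whether the ring has to stay directly attached there.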